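Swapping the Aryl Group on a Hydroxamic Acid Inhibitor

The compounds below may be only part of what the source reports. "The series", "measured", "known", "first", "only" and "open" are said of these compounds alone.

Measured so far:
compound 1, `O=C(NO)c1ccc(/C=C/c2ccnc(-c3ccccc3O)c2)cc1`: 47 nM
compound 2, `COc1ccccc1-c1cc(/C=C/c2ccc(C(=O)NO)cc2)ccn1`: 28 nM
compound 3, `COc1ccc(-c2cc(/C=C/c3ccc(C(=O)NO)cc3)ccn2)cc1`: 110 nM

In an assay on isolated protein for inhibition of protein deacetylase HDAC6 (Homo sapiens), read by fluorescence, with a stated time of 15 min (on this read-out lower numbers stand for stronger inhibition and higher numbers for weaker inhibition), compound 3 stands highest of the three numbers: there is a 2.3-fold higher number from compound 1 to compound 3 (0.37 log units; beyond the scatter) and a 3.9-fold higher number from compound 2 to compound 3 (0.59 log units; beyond the scatter), whereas a 1.7-fold lower number from compound 1 to compound 2 (0.22 log units; within the scatter). Compound 4, `Cc1ccc(-c2cc(/C=C/c3ccc(C(=O)NO)cc3)ccn2)c(F)c1`, differs from compound 3 by 2-fluoro-4-methylphenyl in place of 4-methoxyphenyl on an aromatic carbon. Within the data shown here, no measured step matches this change exactly. The closest guide is a 3.9-fold higher number from compound 2 to compound 3 (0.59 log units; beyond the scatter), a modest step between two groups of equal size on the same carbon; the change to compound 4 is of the same kind, so a modest step is expected rather than a large one, most likely downward. Compound 4 is therefore estimated to give about 60 nM, in the range 25 nM to 150 nM, which corresponds to a 1.8-fold lower number from compound 3 to compound 4 (0.26 log units; within the scatter).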

Compound 4, half-maximal inhibitory concentration: 15 nM
Compound 4: middle estimate off by 4.0-fold (0.60 log units), on the high side; the whole stated range lies above it.
By their numbers in this assay, from the lowest: compounds 4, 2 and 1 (each within the scatter of the next, the first and the last beyond it); then compound 3.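

In this assay, among these compounds, this carbon allows a bigger change than the earlier compounds showed: 2-fluoro-4-methylphenyl for 4-methoxyphenyl, with the same count of heavy atoms, gives a 7.3-fold lower number from compound 3 to compound 4 (0.87 log units; beyond the scatter), the largest step yet. Against the earlier groups, the new one gives a 1.9-fold lower number from compound 2 to compound 4 (0.27 log units; within the scatter), so those two compounds cannot be told apart, and a 3.1-fold lower number from compound 1 to compound 4 (0.50 log units; beyond the scatter). No measurement at hand explains the size of these steps. Whether the fluorine or the methyl matters more remains open, since 2-fluorophenyl and 4-methylphenyl are not among the compounds shown. On these data alone, how an aminophenyl or carboxyphenyl group would read at this carbon also remains open.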